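Methoxy removal in the shared core at one concentration

A few compounds are considered here, and "the series" means these few. Any claim that something is new, unique, unknown or untested is made for them only; others in the source may bear on it.

Three compounds share a core and are measured in a functional assay on MDA-MB-435 cells (Homo sapiens) for cytotoxicity, read by sulforhodamine B assay, with a stated time of 48 h, tested at 0.1 uM; a higher number here means a weaker effect of the compound at the concentration tested, a lower number a stronger effect. Compound 1 `COc1ccc(-c2cc(/C=C/C(=O)c3ccc(N)cc3)[nH]n2)cc1` gives 103%. Compound 2 `COc1ccc(-c2cc(/C=C/C(=O)c3ccc(N)cc3)[nH]n2)cc1OC` gives 98%. Compound 3 `COc1cc(C(=O)/C=C/c2cc(-c3cc(OC)c(OC)c(OC)c3)n[nH]2)cc(OC)c1OC` gives 94%. All three numbers lie within the usual scatter of one another, so no order among them is read.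

Compound 2 and compound 1 differ in one place: hydrogen in place of methoxy on an aromatic carbon. The step of a number 5 percentage points higher from compound 2 to compound 1 (within the scatter) is within the scatter. The difference between the core of compound 2 and the core of compound 3 is not broken down here; their two values show nothing beyond the scatter.

Compound 4 `COc1ccc(-c2cc(/C=C/C(=O)c3cc(OC)c(OC)c(OC)c3)[nH]n2)cc1OC` is not yet measured. It differs from compound 3 in one place: hydrogen in place of methoxy on an aromatic carbon. Among the compounds with values here, this is the same kind of change as the one from compound 2 to compound 1, not the same: in compound 3 the place is also meta to a methoxy group, which is not so in compound 2.

For compound 4 in this assay the step of a number 3 percentage points higher from compound 3 to compound 4 (within the scatter) is expected, resting on the earlier step of a number 5 percentage points higher from compound 2 to compound 1 (within the scatter), which stayed within the scatter. Compound 4 is therefore estimated at 97%, with a range from 87% to 106%.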

Compound 4, a percentage reported as activity, at one concentration (the size of the read-out at that concentration, not a potency): 91%
Compound 4: middle estimate off by 6 percentage points, on the high side; measured number inside the range.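

On the core of compound 3, hydrogen in place of methoxy on an aromatic carbon gives a number 3 percentage points lower from compound 3 to compound 4 (within the scatter) in this assay. Set beside the earlier step on the core of compound 2, the result gives no sign that the outcome of this change depends on the core: the same change on two cores in this assay, a number 5 percentage points higher (within the scatter) from compound 2 to compound 1 and a number 3 percentage points lower (within the scatter) from compound 3 to compound 4, 8 percentage points apart, within the scatter of two such steps What carries from one core to the other is only the absence of a readable effect at this one concentration; the two steps point in opposite printed directions, but that carries no meaning, and neither step gives a size or direction that could be used to predict a further core, nor does this show that the methoxy group would be without consequence at another concentration or in another assay.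

The compounds shown hold only methoxy or hydrogen at the changed place, so the outcome with a hydroxyl group, a fluorine atom or an amine on that aromatic carbon remains open. Going by these compounds, with all the read-outs at a single concentration lying close together, it also remains open whether these compounds would separate from one another at a higher concentration or in a full concentration-response measurement.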